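The source may report more compounds than this note shows. Statements on the series, on what has been measured and on what is new or still open speak of the compounds shown alone.

Compound 2 `CCOc1ncc(-c2nc(C(F)(F)F)sc2N2CCN(C(=O)Cn3c(=O)oc4ccccc43)[C@H](C)C2)cn1` belongs to a pair built on a shared core, the two members differing only in the group attached to the saturated chain carbon bound to the carbonyl carbon. In a functional assay on CHO-K1 cells for antagonist activity at C-X-C chemokine receptor type 3 (Homo sapiens), read by FLIPR, with a stated time of 10 min (on this read-out lower numbers stand for stronger inhibition and higher numbers for weaker inhibition), compound 2 gives 3.3 nM, the higher of the two numbers shown, while compound 1 `CCOc1ncc(-c2nc(C(F)(F)F)sc2N2CCN(C(=O)Cn3cnc4ccccc43)[C@H](C)C2)cn1` gives 2 nM. The change is a 1.7-fold higher number from compound 1 to compound 2 (0.22 log units; within the scatter), so the two compounds stand within the usual scatter of each other.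

Compound 3 `CCOc1ncc(-c2nc(C(F)(F)F)sc2N2CCN(C(=O)Cn3nccc3C)[C@H](C)C2)cn1` has not been measured in this assay. Among the measured compounds shown here, it differs from compound 2 by a group of 6 heavy atoms (4 carbon, 2 nitrogen; one five-membered aromatic ring with 2 hetero atoms) in place of a group of 10 heavy atoms (7 carbon, 1 nitrogen, 2 oxygen; one five-membered aromatic ring with 2 hetero atoms, one six-membered aromatic ring of carbon only), on a saturated chain carbon bound to a carbonyl carbon: a group holding only one five-membered aromatic ring replaces one that also carries a six-membered aromatic ring of carbon only. For the measured compounds named here, the single measured step at this position, a 1.7-fold higher number from compound 1 to compound 2 (0.22 log units; within the scatter), exchanged one two-ring group for another of similar size, and no measured step removes the six-membered ring, so the present change has no direct precedent. Because a 1.7-fold higher number from compound 1 to compound 2 (0.22 log units; within the scatter) lay within the scatter, only a modest shift is expected, more likely toward a higher number, with a wide range. Compound 3 is therefore estimated at 7 nM, between 2 nM and 25 nM. The expected step is a 2.1-fold higher number from compound 2 to compound 3 (0.33 log units; beyond the scatter).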

Compound 3, half-maximal inhibitory concentration: 2 nM
Beside the measured number, compound 3's estimate is 3.5-fold (0.54 log units) above it; measured number inside the range.
By their numbers in this assay, from the lowest: compounds 1, 3 and 2 (each within the scatter of the next).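

At the saturated chain carbon bound to a carbonyl carbon, the six-membered aromatic ring of carbon only can be absent with no change beyond the scatter in this assay: the step that removes it is a 1.7-fold lower number from compound 2 to compound 3 (0.22 log units; within the scatter), and 5-methyl-1H-pyrazol-1-yl in place of 1H-benzimidazol-1-yl gives no change at the digits printed from compound 1 to compound 3 (within the scatter). Among the compounds shown here, the earlier pair had exchanged only one two-ring group for another of similar size, whereas this result extends the comparison to a single-ring group of 6 heavy atoms. All three groups now seen at this position, two carrying that six-membered ring and one without it, stand within the scatter of one another, so in these compounds the number does not follow the presence of that ring. No measurement shown here accounts for this result.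

As far as these compounds go, what remains open is whether the methyl of the 5-methyl-1H-pyrazol-1-yl group matters, and whether a plain 1H-pyrazol-1-yl group, an amine or a carboxylic acid on the same carbon would keep the number in this range. From the compounds shown here alone, all three compounds share the rest of the core, so it is also open whether the same holds with another group in place of the ethoxy or the trifluoromethyl.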